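Shortening the hydroxyalkyl arm: from compound 1 to compound 4

The compounds below may be only part of what the source reports. "The series", "measured", "known", "first", "only" and "open" are said of these compounds alone.

Measured so far in a functional assay on L1210 cells (Mus musculus) for cytotoxicity; on this read-out lower numbers stand for an effect already at smaller amounts and higher numbers for an effect only at larger amounts of compound:
compound 1 `CCCCC(O)C1=CC(=O)c2c(OC)ccc(OC)c2C1=O`: 0.412 ug/mL
compound 2 `COc1cc(CO)c(OC)c2c1C(=O)C=CC2=O`: 0.062 ug/mL
compound 3 `CCCCCCCC(O)c1cc(OC)c2c(c1OC)C(=O)C=CC2=O`: 0.274 ug/mL

Compound 1 holds the highest of the three numbers in this assay. Its nearest neighbour is compound 3, and the two lie within the scatter of each other; compound 2 stands apart from both with the lowest number, its gaps to compound 1 and to compound 3 being beyond the scatter.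

Compound 4 `COc1ccc(OC)c2c1C(=O)C=C(C(C)O)C2=O` differs from compound 1 by a single change: hydrogen in place of propyl on a saturated chain carbon, two bonds along the chain from a double-bonded ring carbon and an oxygen on a saturated carbon.

Among the compounds with values here, only one measured step speaks to a change of chain length at a saturated carbon carrying an oxygen: a 4.4-fold higher number from compound 2 to compound 3 (0.65 log units; beyond the scatter). That step added carbons and the number went up. Within the data shown here, the change from compound 1 to compound 4 removes carbons, so the reverse direction is the natural expectation, but the single precedent sits at a different place and involves a longer chain, so the transfer is loose.

For compound 4 the expectation is a modestly lower number than compound 1, a step of a 2.1-fold lower number from compound 1 to compound 4 (0.31 log units; beyond the scatter), giving an estimated 0.2 ug/mL with a range from 0.08 ug/mL to 0.5 ug/mL.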

Compound 4, concentration for half-maximal effect: 0.487 ug/mL
For compound 4 the middle estimate is 2.4-fold (0.39 log units) below the measured one, and the stated range covers the measured number.
By their numbers in this assay, from the lowest: compound 2; then compounds 3, 1 and 4 (each within the scatter of the next).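

In this assay, hydrogen in place of propyl on this saturated chain carbon gives a 1.2-fold higher number from compound 1 to compound 4 (0.07 log units; within the scatter), so the read-out does not separate 1-hydroxypentyl from 1-hydroxyethyl on the shared core. Within the data shown here, the only earlier step involving chain length, a 4.4-fold higher number from compound 2 to compound 3 (0.65 log units; beyond the scatter), lies beyond the scatter but sits at a different place on the core, and its size does not carry over to this position: here, cutting butyl back to methyl on the carbon bearing the oxygen leaves compound 4 within the scatter of compound 1, and the arm tolerates this change with no measurable consequence in this assay. No available measurement accounts for this result.

Open, on these data alone, is whether a longer chain than butyl on this carbon, for instance octyl, would stay within the scatter of compound 1 or move the number beyond it. Equally open, as far as these compounds go, is whether an amine or a carboxylic acid in place of the hydroxyl on this arm would leave the number where compound 1 and compound 4 stand.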